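Methoxy to hydroxy on the shared core: an estimate

A few compounds are considered here, and "the series" means these few. Any claim that something is new, unique, unknown or untested is made for them only; others in the source may bear on it.

Measured compounds in a functional assay on EC9706 cells (Homo sapiens) for cytotoxicity, read by MTT assay, with a stated time of 72 h; on this read-out higher numbers stand for weaker inhibition and lower numbers for stronger inhibition:
Compound 1 `O=C(CSC(=S)N[C@H]1CCOC1=O)Nc1ccccc1F`: > 128000 nM, a limit of the assay.
Compound 2 `O=C(CSC(=S)N[C@H]1CCOC1=O)Nc1cccc(Cl)c1`: 107000 nM.
Compound 3 `COc1ccc(NC(=O)CSC(=S)N[C@H]2CCOC2=O)cc1`: > 128000 nM, a limit of the assay.

Among the measured compounds shown here, compound 3 stands at the limit of the assay, so only a bound is known for it, and the limit of > 128000 nM in this assay, at which 2 of the 3 values shown sit, shows that it shares this bound with compound 1, while compound 2 is the one measured compound with a number. Compound 4 `O=C(CSC(=S)N[C@H]1CCOC1=O)Nc1ccc(O)cc1` differs from compound 3 by hydrogen in place of methyl on an oxygen on an aromatic ring. For the measured compounds named here, the only measured step, an at least 1.1-fold lower number from compound 1 to compound 2 (0.07 log units; that floor lies within the scatter), concerns an exchange on the amide-type nitrogen, lies within the scatter, and tells nothing about removing a methyl from an oxygen. Going by the values given here, with no step bearing on this change, the expectation for compound 4 rests on where compound 3 sits: the expected step of a number no higher from compound 3 to compound 4 (the limit leaves the size open) is none beyond the scatter. Compound 4 is therefore estimated at 128000 nM, within 60000 nM to 300000 nM, most likely reported again as a limit.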

Compound 4, half-maximal inhibitory concentration: > 128000 nM
Compound 4 gave a limit, no number (the forecaster's own chance of this, stated with the estimate: 70%); the middle value sits exactly at the limit.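

In this assay compound 4 gives > 128000 nM, which is a limit of the assay and not a number. Neither methoxy nor hydroxy at this place on the aromatic ring yields a measured number, and the steps from compound 3 and from compound 1 to compound 4 cannot be read, as both ends of each are limits. The one step that can be read is an at least 1.1-fold higher number from compound 2 to compound 4 (0.07 log units; that floor lies within the scatter), and the limit is now the common result of this small set: the limit of > 128000 nM in this assay, at which 3 of the 4 values shown sit.

As far as these compounds go, the real size of the change from methoxy to hydroxy stays unknown, as does any difference between compound 3 and compound 4. Also open, from the compounds shown here alone, is whether an amine or a carboxylic acid in place of the hydroxy on the aromatic ring would give a number in this assay.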